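The source may report more compounds than this note shows. Statements on the series, on what has been measured and on what is new or still open speak of the compounds shown alone.

Working notes on the series. Compound 1 `CC(=O)OC/C(=C\C1CCCCC1)C(=O)c1ccccc1` is the reference point. Within the data shown here, in a functional assay on T47D cells (Homo sapiens) for inhibition, read by sulforhodamine B assay, with a stated time of 48 h (a higher number here means a weaker inhibitor of growth, a lower number a stronger inhibitor of growth), compound 1 gives 22000 nM, the highest of the two numbers measured so far. Among the measured compounds shown here, its nearest neighbour is compound 2 `CC(=O)OC/C(=C\c1ccccc1)C(=O)c1ccccc1`, which in this assay gives 16000 nM; the only step measured in the set, a 1.4-fold lower number from compound 1 to compound 2 (0.14 log units; within the scatter), concerns the group on the double-bonded chain carbon and leaves the two values within the scatter of each other.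

Compound 3 `CC(=O)OC/C(=C\C1CCCCC1)C(=O)c1ccc(Cl)cc1` is not yet measured. It differs from compound 1 in one place: chloro in place of hydrogen on an aromatic carbon, on an aromatic carbon of a six-membered aromatic ring of carbon only. For the measured compounds named here, no measured step touches this ring, so nothing in the set speaks directly to the change. Going by the values given here, the one step available, a 1.4-fold lower number from compound 1 to compound 2 (0.14 log units; within the scatter), was within the scatter, and the set as a whole shows no movement beyond it. No step beyond the scatter is therefore expected in this assay, in either direction. The value expected for compound 3 is 20000 nM, with a range of 8000 nM to 50000 nM. This estimate amounts to a 1.1-fold lower number from compound 1 to compound 3 (0.04 log units; within the scatter), which is expected to fall within the scatter.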

Compound 3, concentration for 50% growth inhibition: 18000 nM
Compound 3: the middle estimate sits 1.1-fold (0.05 log units) above what was measured; the measured number falls inside the stated range.
By their numbers in this assay, from the lowest: compounds 2, 3 and 1 (each within the scatter of the next).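

In this assay, among these compounds, chloro in place of hydrogen on an aromatic carbon, para to a large group, gives a 1.2-fold lower number from compound 1 to compound 3 (0.09 log units; within the scatter) and so provides the first reading on this ring, which the earlier step did not touch. Set beside the change at the double-bonded chain carbon (a 1.4-fold lower number from compound 1 to compound 2 (0.14 log units; within the scatter)), it means that a change in each of two separate places on the core of compound 1 has now been read, and neither moves the number beyond the scatter, though this rests on a single substituent at a single ring position. No measurement at hand offers an explanation for this result.

The compounds shown leave open whether a group of a different kind at this ring position, such as an amine, a carboxylic acid or a methoxy group, would give a step beyond the scatter, and whether chloro would behave the same way on the core of compound 2. As far as these compounds go, the acetate end of the chain also remains unexplored, so a longer chain or a free alcohol there could still give a different picture.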